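The compounds below may be only part of what the source reports. "The series", "measured", "known", "first", "only" and "open" are said of these compounds alone.

Compound 1 `CC(C(=O)N1CCN(c2ccccc2)CC1)N1C(=O)CCC1=O` gives 50% in a functional assay on the whole organism (strain Swiss) with Mus musculus as the target, in the maximal electroshock model, with a stated time of 0.5 h, at a dose of 300 mg/kg by the intraperitoneal route; a higher number here means a stronger effect of the compound at the dose given, a lower number a weaker effect.
Compound 2 `CC(C(=O)N1CCN(c2ccc(Cl)cc2)CC1)N1C(=O)CCC1=O` gives 100%.
Compound 3 `CC(C(=O)N1CCN(c2ccccc2C(F)(F)F)CC1)N1C(=O)CCC1=O` gives 100%.

Compound 3 stands level with compound 2 at the digits shown, and together they are the highest of the three numbers; the gap that separates them from compound 1 is a number 50 percentage points higher from compound 1 to compound 3 (beyond the scatter). Compound 4 `CC(C(=O)N1CCN(c2ccccc2Cl)CC1)N1C(=O)CCC1=O` differs from compound 3 in one place: chloro in place of trifluoromethyl on an aromatic carbon.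

Among the measured compounds shown here, two measured steps bear on this change. Chloro in place of hydrogen on an aromatic carbon gave a number 50 percentage points higher from compound 1 to compound 2 (beyond the scatter), and trifluoromethyl in place of hydrogen on an aromatic carbon gave a number 50 percentage points higher from compound 1 to compound 3 (beyond the scatter). For the measured compounds named here, both groups thus carried the read-out from the value of compound 1 to the top of the range seen here, and no step between chloro and trifluoromethyl themselves has been measured. On these numbers no step beyond the scatter is expected in this assay; the step from compound 3 to compound 4 is estimated at a number 10 percentage points lower from compound 3 to compound 4 (within the scatter). Compound 4 is therefore expected to give about 90%, with a range from 60% to 100%.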

Compound 4, a percentage reported as activity, at one dose (the size of the read-out at that dose, not a potency): 0%
For compound 4 the middle estimate is 90 percentage points above the measured one, and the stated range ends above it.
By their numbers in this assay, from the lowest: compound 4; then compound 1; then compounds 2 and 3 (each within the scatter of the next).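

In this assay, among the compounds shown here, trifluoromethyl and chloro are not interchangeable on this aromatic carbon, ortho to a large group: the exchange gives a number 100 percentage points lower from compound 3 to compound 4 (beyond the scatter) and is the first change here to bring the read-out down. Where the chloro sits also decides its effect, with 2-chlorophenyl in place of 4-chlorophenyl giving a number 100 percentage points lower from compound 2 to compound 4 (beyond the scatter), while chloro at this place, in place of hydrogen, gives a number 50 percentage points lower from compound 1 to compound 4 (beyond the scatter) and so turns a gain seen with the other placement into a loss. Nothing measured here explains these differences.

Going by these compounds, whether a methyl or a methoxy group at this place would follow trifluoromethyl or chloro remains open. So does the outcome for 3-chlorophenyl, and since each compound is read at a single dose, these numbers say nothing about potency.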